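The compounds below may be only part of what the source reports. "The series", "measured", "known", "first", "only" and "open" are said of these compounds alone.

Measured compounds:
- compound 1, `COc1cccc(OC)c1OCCNCCOc1ccccc1OCc1ccc(Cl)cc1`: 8.17
- compound 2, `COc1cccc(OC)c1OCCNCCOc1ccccc1OCc1cccc(C)c1`: 8.3
- compound 3, `COc1cccc(OC)c1OCCNCCOc1ccccc1OCc1ccc(C)cc1`: 8.23

In a functional assay on Vas deferens for antagonist activity at Alpha-1A adrenergic receptor (Rattus norvegicus) (a higher number here means a more potent compound, by a factor of ten per unit of this negative logarithm, a lower number a less potent compound), compound 1 gives 8.17, the lowest of the three numbers, though its two neighbours lie within the scatter of it: compound 3 is nearest and compound 2 furthest away. The step from compound 1 to compound 4, `COc1cccc(COc2ccccc2OCCNCCOc2c(OC)cccc2OC)c1`, exchanges the ring that hangs on the saturated chain carbon bound to an oxygen on an aromatic ring: 3-methoxyphenyl in place of 4-chlorophenyl on a saturated chain carbon bound to an oxygen on an aromatic ring. Among the compounds with values here, two measured steps touch this same position. The step of a number 0.13 log units higher from compound 1 to compound 2 (within the scatter) and the step of a number 0.07 log units lower from compound 2 to compound 3 (within the scatter) both stay within the scatter, and the step of a number 0.06 log units higher from compound 1 to compound 3 (within the scatter) does likewise, so the three substituents tried so far on that ring leave this assay essentially untouched. Within the data shown here, the methoxy group entering in compound 4 has not been tested at this position, so no measured step shows its own effect; the expectation therefore rests on the flatness seen so far. Compound 4 is expected to stay within the scatter of compound 1, a step of a number 0.03 log units higher from compound 1 to compound 4 (within the scatter). The estimate for compound 4 in this assay is 8.2, with a range from 7.7 to 8.7.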

Compound 4, negative logarithm of the antagonist equilibrium constant: 8.3
For compound 4 the middle estimate is 0.10 log units below the measured one; low and high end bracket the measured number.
By their numbers in this assay, from the lowest: compounds 1, 3, 2 and 4 (each within the scatter of the next).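

In this assay the 3-methoxyphenyl ring, the first one here with a hydrogen-bond acceptor, joins the flat set: exchanging the 4-chlorophenyl ring gives a number 0.13 log units higher from compound 1 to compound 4 (within the scatter), and exchanging the 4-methylphenyl ring gives a number 0.07 log units higher from compound 3 to compound 4 (within the scatter). The direct comparison of the two groups on the same ring, methoxy in place of methyl, gives no change at the digits printed from compound 2 to compound 4 (within the scatter), so at this position the added oxygen and the hydrogen-bond acceptor counted with it go with no step beyond the scatter. Nothing available explains this flatness.

The compounds shown leave open whether a carboxylic acid or an amine on this ring would also stay within the scatter of compound 1. They also leave open whether a longer chain between the ring and the oxygen on the aromatic ring would do so.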